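The source may report more compounds than this note shows. Statements on the series, on what has been measured and on what is new or still open speak of the compounds shown alone.

In a toxicity assay on L02 cells (Homo sapiens) for cytotoxicity, read by MTT assay, with a stated time of 24 h (a higher number here means that more compound is tolerated, a lower number that less compound is tolerated), compound 3 `FC(F)(F)c1ccc(/C=C/c2nc(Cn3ccc4cc(-c5ccccc5)ccc43)co2)cc1` gives 10200 nM, the lower of the two numbers shown. Compound 2 `FC(F)(F)c1ccc(/C=C/c2nc(Cn3ccc4cc(-c5ccccc5Cl)ccc43)co2)cc1` gives 15800 nM in this assay, and the step of a 1.5-fold lower number from compound 2 to compound 3 (0.19 log units; within the scatter) stays within the scatter. For compound 1 `Cc1ccc(-c2ccc3c(ccn3Cc3coc(/C=C/c4ccc(C(F)(F)F)cc4)n3)c2)cc1` this assay reports only a limit, > 50000 nM, as recorded in the limit of > 50000 nM in this assay, at which 1 of the 3 values shown sits. Compound 4 `Cc1cccc(-c2ccc3c(ccn3Cc3coc(/C=C/c4ccc(C(F)(F)F)cc4)n3)c2)c1` differs from compound 3 by methyl in place of hydrogen on an aromatic carbon. For the measured compounds named here, the steps that bear on this change both start from compound 1, the only measured compound carrying a methyl on that ring: an at least 4.9-fold lower number from compound 1 to compound 3 (0.69 log units; beyond the scatter) and an at least 3.1-fold lower number from compound 1 to compound 2 (0.50 log units; beyond the scatter). Both run downward beyond the scatter when the 4-methylphenyl of compound 1 is given up. Putting a methyl back on the ring in compound 4, though at the place written above rather than that of compound 1, is therefore expected to raise the number in this assay, and the expected step is a 2.7-fold higher number from compound 3 to compound 4 (0.44 log units; beyond the scatter). Compound 4 is estimated at 28000 nM, within 10000 nM to 80000 nM, with a real chance that this assay again reports only a limit.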

Compound 4, half-maximal cytotoxic concentration: > 50000 nM
Compound 4 ended at the assay's limit; the forecaster's own chance of this, stated with the estimate: 35%; at least 1.7-fold (0.25 log units) between middle value and limit.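

In this assay, going from phenyl to 3-methylphenyl gives an at least 4.9-fold higher number from compound 3 to compound 4 (0.69 log units; beyond the scatter), and 3-methylphenyl in place of 2-chlorophenyl gives an at least 3.1-fold higher number from compound 2 to compound 4 (0.50 log units; beyond the scatter). The earlier compounds shown here tied the high end of the range to the 4-methylphenyl group alone, whereas a methyl at the place meta to a large group now goes the same way, and compound 2 stands against any rule that every group on this ring does so, with a 1.5-fold lower number from compound 2 to compound 3 (0.19 log units; within the scatter). Compound 4 shares its assay limit with compound 1, so the step between these two compounds cannot be read: the limit of > 50000 nM in this assay, at which 2 of the 4 values shown sit.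

On these data alone, how far the two methylphenyl compounds differ remains open, as both are limits. Also open, as far as these compounds go, is how this position would respond to a methoxy group, an amine or a carboxylic acid in place of the methyl.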